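Chloro to methoxy on an ester-linked anilide series

A few compounds are considered here, and "the series" means these few. Any claim that something is new, unique, unknown or untested is made for them only; others in the source may bear on it.

Compound 1 `COCOc1cc(/C=C/C(=O)OCC(=O)Nc2ccc(OC)cc2)ccc1OCc1ccccc1`, compound 2 `COCOc1cc(/C=C/C(=O)OCC(=O)Nc2ccc(Cl)cc2)ccc1OCc1ccccc1` and compound 3 `O=C(COC(=O)/C=C/c1ccc(O)c(O)c1)Nc1ccc(Cl)cc1` were tested in a functional assay on K562 cells (Homo sapiens) for cytotoxicity, read by MTT assay, with a stated time of 72 h; on this read-out lower numbers stand for stronger inhibition and higher numbers for weaker inhibition. In this assay compound 1 reaches only a limit of the assay, > 200000 nM, and no number. In this assay compound 2 likewise gives only a limit, > 200000 nM. In this assay compound 3 gives 99400 nM. Compound 2 and compound 1 differ in one place, (methoxy in place of chloro on an aromatic carbon), and the step that the two limits leave unreadable from compound 2 to compound 1 yields no readable size. How the core of compound 3 differs from the core of compound 2 is not broken down here.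

Compound 4 `COc1ccc(NC(=O)COC(=O)/C=C/c2ccc(O)c(O)c2)cc1` has not yet been measured. It stands to compound 3 as compound 1 stands to compound 2, by methoxy in place of chloro on an aromatic carbon, the same change at the same place. For the measured compounds named here, since the earlier step gives no size, the expectation for compound 4 rests on compound 3 with its value 99400 nM, the only number in the set. It also takes account of the limit of > 200000 nM in this assay, at which 2 of the 3 values shown sit, which makes a limit for compound 4 a real possibility. In this assay compound 4 is expected near 130000 nM, with a range from 50000 nM to 300000 nM. The estimated step of a 1.3-fold higher number from compound 3 to compound 4 (0.12 log units; within the scatter) stays within the usual scatter of such measurements.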

Compound 4, half-maximal inhibitory concentration: 79100 nM
Compound 4: the middle estimate sits 1.6-fold (0.22 log units) above what was measured; the measured number falls inside the stated range.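

On the core of compound 3, methoxy in place of chloro, which turns the 4-chlorophenyl group into 4-methoxyphenyl, gives in this assay a 1.3-fold lower number from compound 3 to compound 4 (0.10 log units; within the scatter), so on this core the change has no readable effect. The same change on the core of compound 2 cannot be read, because compound 2 and compound 1 each give only a limit of the assay and no number: the limit of > 200000 nM in this assay, at which 2 of the 4 values shown sit. The set therefore holds a single readable step, which describes the change on one core only and does not show whether it would behave alike on the other, so no transfer from one core to another can be claimed or ruled out.

The compounds shown carry only chloro or methoxy on this aromatic carbon, which leaves open what an amine, a nitrile or a carboxylic acid would give at that place on the core of compound 3. Equally open, on these data alone, is what a longer chain in place of the methoxy would give, and whether any such group would bring a readable number on the core of compound 2.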